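The compounds below may be only part of what the source reports. "The series", "measured", "known", "first", "only" and "open" are said of these compounds alone.

Compound 2 `CN(C)c1ccc(C2CC(c3ccccn3)=NN2c2ccccc2)cc1` stands highest of the three compounds measured in a functional assay on the whole organism (strain Charles Foster albino) for inhibition, with Rattus norvegicus as the target, read by paw edema, with stated times of 30 min and 3 h, at a dose of 50 mg/kg by the oral route (a higher number here means more inhibition at the dose given (going by the name of the read-out), a lower number less inhibition), where compound 2 gives 35%. Compound 3 `COc1ccc(OC)c(C2CC(c3ccncc3)=NN2c2ccccc2)c1` comes nearest, and in this assay compound 3 gives 18%, a gap beyond the usual scatter. Compound 1 `CN(C)c1ccc(C2CC(c3ccncc3)=NN2)cc1` lies furthest away, and in this assay compound 1 gives 0%, again beyond the scatter. Compound 1 shares with the unmeasured compound a hydrogen on the amine nitrogen in the ring, though it differs from compound 2 in more than that single place, so no single step can be read from it.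

Compound 4 `CN(C)c1ccc(C2CC(c3ccccn3)=NN2)cc1` is the unmeasured compound. It differs from compound 2 in one place: hydrogen in place of phenyl on an amine nitrogen in a ring. Going by the values given here, no step of this kind stands among the measured pairs. The writer expects the step from compound 2 to compound 4 to be a loss in this assay, beyond the scatter, amounting to a number 23 percentage points lower from compound 2 to compound 4 (beyond the scatter). For compound 4 the estimated value in this assay is 12%, in a range from 0% to 30%.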

Compound 4, a percentage reported as inhibition, in the whole organism at one dose (the size of the read-out at that dose, not a potency): 18%
Compound 4: the middle estimate sits 6 percentage points below what was measured; the range from low to high includes it.
By their numbers in this assay, from the lowest: compound 1; then compounds 3 and 4 (each within the scatter of the next); then compound 2.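

In this assay the phenyl on the amine nitrogen in the ring now has a step of its own: hydrogen in its place gives a number 17 percentage points lower from compound 2 to compound 4 (beyond the scatter), yet compound 4 still gives 18%, so with the pyridin-2-yl group present the read-out does not depend on that phenyl alone. The carbon with a double bond to nitrogen also gets its first single-place comparison, as pyridin-2-yl in place of pyridin-4-yl gives a number 18 percentage points higher from compound 1 to compound 4 (beyond the scatter), which shows that the choice between these two groups counts when hydrogen sits on the amine nitrogen. No measurement at hand explains either step.

From the compounds shown here alone, whether the same pyridinyl change holds when phenyl sits on the amine nitrogen stays open. So does how an acetyl or a methyl group on that nitrogen would compare with phenyl and hydrogen.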